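Swapping Nitro for Fluoro on a Weak Cytotoxic Scaffold

The source may hold more compounds than are shown below. What is called first, only, known or untested is meant among the compounds shown, and "the series" means these compounds.

Compound 3 `O=c1nc2ccc(Cl)cn2cc1Cc1ccc([N+](=O)[O-])cc1` is one of three compounds tested in a functional assay on HeLa cells (Homo sapiens) for cytotoxicity, read by MTT assay, with a stated time of 24 h; a higher number here means a weaker inhibitor, a lower number a stronger inhibitor. Compound 3 gives 928000 nM, the highest of the two plain numbers shown. Compound 2 `O=c1nc2ccccn2cc1Cc1ccc(F)cc1` carries a fluoro group on a core that lacks the chloro of compound 3. Compound 2 gives 139000 nM. Compound 1 `Cc1ccc(Cc2cn3cc(Cl)ccc3nc2=O)cc1` is reported in this assay only as a limit, > 1000000 nM.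

The step under study leads to compound 4 `O=c1nc2ccc(Cl)cn2cc1Cc1ccc(F)cc1`, where (fluoro in place of nitro on an aromatic carbon). For the measured compounds named here, one measured step touches the same position: from compound 1 to compound 3 the change was an at least 1.0-fold lower number from compound 1 to compound 3 (0.03 log units; that floor lies within the scatter), a step whose true size is hidden because compound 1 sits at the limit of > 1000000 nM in this assay, at which 1 of the 3 values shown sits. Compound 2 carries the same fluoro as compound 4, but on a different core, so its value gives only a loose pointer toward a lower number. Weighing these, the step from compound 3 to compound 4 is estimated as a 3.1-fold lower number from compound 3 to compound 4 (0.49 log units; beyond the scatter). Compound 4 is therefore expected to give about 300000 nM in this assay, within a range from 60000 nM to 1000000 nM.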

Compound 4, half-maximal inhibitory concentration: > 1000000 nM
Compound 4 ended at the assay's limit; the forecaster's own chance of this, stated with the estimate: 25%; middle value at least 3.3-fold (0.52 log units) from the limit.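

In this assay fluoro in place of nitro on this aromatic carbon gives an at least 1.0-fold higher number from compound 3 to compound 4 (0.03 log units; that floor lies within the scatter) and so shows no readable drop, which the fluoro of compound 2 had seemed to promise. For the compounds shown here, with fluoro kept, chloro in place of hydrogen on an aromatic carbon gives an at least 7.1-fold higher number from compound 2 to compound 4 (0.85 log units; beyond the scatter) and is the only readable step here, so the lower number of compound 2 goes with its core lacking chloro, not with fluoro alone. The step between compound 1 and compound 4 cannot be read, and the true size of the nitro to fluoro change stays hidden, because of the assay's ceiling: (the limit of > 1000000 nM in this assay, at which 2 of the 4 values shown sit).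

Going by these compounds, how far compound 3 and compound 4 really lie apart remains open. So does whether an amine or a carboxylic acid at this aromatic carbon would bring the chloro core into a readable range.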